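From amino to hydroxy on the shared core

A few compounds are considered here, and "the series" means these few. Any claim that something is new, unique, unknown or untested is made for them only; others in the source may bear on it.

In a functional assay on A549 cells (Homo sapiens) for cytotoxicity, read by MTT assay, with a stated time of 48 h (a higher number here means a weaker inhibitor, a lower number a stronger inhibitor), compound 1 `COc1ccc(-c2cn(C(=O)Nc3cc(OC)c(OC)c(OC)c3)c(=O)n2-c2cc(OC)c(OC)c(OC)c2)cc1` gives > 50000 nM, which is a limit of the assay. Among the compounds with values here, compound 2 `COc1ccc(-c2cn(C(=O)Nc3cc(OC)c(OC)c(OC)c3)c(=O)n2-c2cc(OC)c(OC)c(OC)c2)cc1N` gives 11100 nM, the only actual number so far. Within the data shown here, the one measured step shows an at least 4.5-fold lower number from compound 1 to compound 2 (0.65 log units; beyond the scatter), with amino in place of hydrogen on an aromatic carbon.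

Compound 3 `COc1ccc(-c2cn(C(=O)Nc3cc(OC)c(OC)c(OC)c3)c(=O)n2-c2cc(OC)c(OC)c(OC)c2)cc1O` keeps the core and changes one group: hydroxy in place of amino on an aromatic carbon. This turns 3-amino-4-methoxyphenyl into 3-hydroxy-4-methoxyphenyl. Among the measured compounds shown here, no measured step exchanges these two groups, so only the step from hydrogen to amino bears on this change, and it shows only that this place can move the number. A small rise in this assay is therefore expected, with a real chance of reaching the limit. The expected move is a 1.4-fold higher number from compound 2 to compound 3 (0.16 log units; within the scatter). For compound 3 the estimate is 16000 nM, with an expected range of 5000 nM to 50000 nM.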

Compound 3, half-maximal inhibitory concentration: > 50000 nM
Compound 3 gave a limit, no number; the forecaster's own chance of this, stated with the estimate: 25%; middle value at least 3.1-fold (0.49 log units) from the limit.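

Exchanging amino for hydroxy on this carbon is not a neutral swap: in this assay the change gives an at least 4.5-fold higher number from compound 2 to compound 3 (0.65 log units; beyond the scatter), so the number depends on which group sits here, not only on whether hydrogen has been replaced. Hydroxy and amino match in the heavy-atom, hydrogen-bond donor and hydrogen-bond acceptor counts, so those counts do not separate compound 2 from compound 3. The step from compound 1 to compound 3 cannot be read, since compound 1 and compound 3 both stand at a limit: the limit of > 50000 nM in this assay, at which 2 of the 3 values shown sit.

From the compounds shown here alone, how far compound 3 lies beyond its limit stays open. So does whether the gain in compound 2 needs a free amino group, since the compounds shown do not tell how a methylamino or acetamide group at this place would read in this assay.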